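This account rests on a few compounds, and the source may have more. Where it says the series, first, only, none or still open, it means among the compounds named here.

Working notes on the series. Three compounds have numbers in an assay on isolated protein for inhibition of G protein-coupled receptor kinase 6 (Homo sapiens), read by scintillation counting, radiometric assay and 33P incorporation, with a stated time of 80 min, in the presence of a further agent that is not named here; a higher number here means a weaker inhibitor, a lower number a stronger inhibitor. Compound 1 `CCc1cc(Nc2nc(N[C@@H](C)c3ccc(F)cn3)nc3cccc(F)c23)n[nH]1` gives 29 nM. Compound 2 `CCc1cc(Nc2nc(N[C@@H](C)c3ccc(Cl)cc3)nc3ccccc23)n[nH]1` gives 70 nM. Compound 3 `CCc1cc(Nc2nc(N[C@@H](C)c3ccc(F)cc3)nc3ccc(OC)cc23)n[nH]1` gives 140 nM, the highest number of the three; the gap to compound 2 lies within the scatter, so the two cannot be ordered, while the gap to compound 1 lies beyond it, so compound 3 is the weaker inhibitor of that pair.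

Compound 4 `CCc1cc(Nc2nc(N[C@@H](C)c3ccc(F)cc3)nc3ccc(F)cc23)n[nH]1` differs from compound 3 in one place: fluoro in place of methoxy on an aromatic carbon. Going by the values given here, no pair of measured compounds shows this exchange on its own, so no measured step can be borrowed. The reading is that compound 4 should sit in this assay in the range spanned by compound 2 and compound 3, with room for a modestly lower number because compound 1, which also carries a fluoro on the shared core, gives 29 nM. Compound 4 is therefore expected at 80 nM, within 35 nM to 180 nM, which means an estimated step of a 1.8-fold lower number from compound 3 to compound 4 (0.24 log units; within the scatter) from compound 3 to compound 4, a change that may not exceed the scatter.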

Compound 4, half-maximal inhibitory concentration: 160 nM
The estimate for compound 4 lay 2.0-fold (0.30 log units) below the measured number; low and high end bracket the measured number.
By their numbers in this assay, from the lowest: compound 1; then compounds 2, 3 and 4 (each within the scatter of the next, the first and the last beyond it).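

In this assay, fluoro in place of methoxy on this aromatic carbon gives a 1.1-fold higher number from compound 3 to compound 4 (0.06 log units; within the scatter), so the two groups cannot be told apart at this position. The exchange removes the hydrogen-bond acceptor counted for methoxy and shortens the substituent to a single atom, yet the step stays within the scatter. No available evidence bears on why the two groups read alike.

Going by these compounds, it remains open whether an amine, a carboxylic acid or a longer chain such as butoxy on the same aromatic carbon would give a step beyond the scatter. The exchange also appears only once among the compounds shown, so it is unknown whether fluoro and methoxy would read alike elsewhere on the shared core or with a different group on the remainder of the molecule.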